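The source may report more compounds than this note shows. Statements on the series, on what has been measured and on what is new or still open speak of the compounds shown alone.

The measured compounds:
Compound 1 `O=Cc1ccc(-c2cn3ccnc3c(-c3ccc4ncn(C5CCCCC5)c4c3)n2)cc1` gives 37.8% in a functional assay on NCI-H460 cells (Homo sapiens) for inhibition, read by sulforhodamine B assay, with a stated time of 48 h, tested at 10 uM; a higher number here means more inhibition at the concentration tested (going by the name of the read-out), a lower number less inhibition.
Compound 2 `Fc1ccc(-c2cn3ccnc3c(-c3ccc4ncn(C5CCCCC5)c4c3)n2)cc1` gives 6.12% in this assay.

Within the data shown here, compound 1 stands highest of the two numbers, and the only step away from it is a number 31.7 percentage points lower from compound 1 to compound 2 (beyond the scatter), a large fall. Compound 3 `CC(=O)c1ccc(-c2cn3ccnc3c(-c3ccc4ncn(C5CCCCC5)c4c3)n2)cc1` has not yet been measured. It differs from compound 1 in one place: methyl in place of hydrogen on a carbonyl carbon. Among the measured compounds shown here, the one measured step that bears on this change is the one in which the formyl group, carbonyl and all, gives way to fluoro, namely a number 31.7 percentage points lower from compound 1 to compound 2 (beyond the scatter). In compound 3, by contrast, the carbonyl is kept and only a methyl is added to it, so the change is smaller than the one already seen. A step in this assay of no more than modest size, downward or none beyond the scatter, is therefore expected, estimated at a number 5.8 percentage points lower from compound 1 to compound 3 (within the scatter). Compound 3 is expected to give about 32%, within a range of 12% to 52%.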

Compound 3, a percentage reported as inhibition, at one concentration (the size of the read-out at that concentration, not a potency): 7.12%
For compound 3 the middle estimate is 24.9 percentage points above the measured one; measured number outside the range, below it.
By their numbers in this assay, from the lowest: compounds 2 and 3 (each within the scatter of the next); then compound 1.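

Methyl in place of hydrogen on the carbonyl carbon gives a number 30.7 percentage points lower from compound 1 to compound 3 (beyond the scatter) in this assay, so keeping the carbonyl is not enough to hold the number in this series. Acetyl in place of fluoro on the aromatic carbon gives a number 1 percentage points higher from compound 2 to compound 3 (within the scatter), which leaves those two groups indistinguishable here and compound 1, with its formyl group, alone in standing apart from both others. Nothing measured on these compounds accounts for the loss on going from formyl to acetyl.

On these data alone, it remains open whether the higher number is peculiar to the formyl group or is shared by other groups on this aromatic carbon, such as a carboxylic acid, a hydroxymethyl or an amine. The effect of a longer chain on the carbonyl carbon, or of an amine there in place of methyl, is also left open.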